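The source may hold more compounds than are shown below. What is called first, only, known or untested is meant among the compounds shown, and "the series" means these compounds.

Three compounds of the series carry numbers in a functional assay on MCF7 cells (Homo sapiens) for cytotoxicity, read by MTT assay, with a stated time of 72 h; a higher number here means a weaker inhibitor, a lower number a stronger inhibitor. Compound 1 `CN1[C@@H]2c3[nH]c4ccccc4c3C[C@H]1[C@H](C#N)N1[C@@H](CNC(=O)c3cc4ccccc4o3)c3[nH]c4ccccc4c3C[C@@H]21` gives 320 nM. Compound 2 `CN1[C@@H]2c3[nH]c4ccccc4c3C[C@H]1[C@H](C#N)N1[C@@H](CNC(=O)c3cc4ccccc4[nH]3)c3[nH]c4ccccc4c3C[C@@H]21` gives 9780 nM. Compound 3 `CN1[C@@H]2c3[nH]c4ccccc4c3C[C@H]1[C@H](C#N)N1[C@@H](CNC(=O)/C=C/c3cccc(C(F)(F)F)c3)c3[nH]c4ccccc4c3C[C@@H]21` gives 110 nM, the lowest of the three numbers. Every measured step exchanges the whole group on the amide carbonyl: a 31-fold higher number from compound 1 to compound 2 (1.49 log units; beyond the scatter), a 2.9-fold lower number from compound 1 to compound 3 (0.46 log units; beyond the scatter) and an 89-fold lower number from compound 2 to compound 3 (1.95 log units; beyond the scatter). Compound 3 therefore stands apart from compound 1 by a modest margin and from compound 2 by a large one.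

Compound 4 `CN1[C@@H]2c3[nH]c4ccccc4c3C[C@H]1[C@H](C#N)N1[C@@H](CNC(=O)/C=C/c3ccccc3)c3[nH]c4ccccc4c3C[C@@H]21` differs from compound 3 in one place: hydrogen in place of trifluoromethyl on an aromatic carbon. Among the measured compounds shown here, none of the measured steps removes or adds a substituent on this six-membered ring; each swaps the entire group on the carbonyl carbon, and the series holds no step of the smaller kind now in question. The measured steps show that this assay answers strongly to what sits on the carbonyl, but they give no direction for loss of the trifluoromethyl. With nothing closer to go on, a small change is expected, most likely toward a somewhat higher number, with a wide range on either side. Compound 4 is estimated at 220 nM, with a range from 70 nM to 700 nM. The expected step is a 2.0-fold higher number from compound 3 to compound 4 (0.30 log units; within the scatter).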

Compound 4, half-maximal inhibitory concentration: 7190 nM
Compound 4: the middle estimate sits 33-fold (1.51 log units) below what was measured, and the stated range ends below it.
By their numbers in this assay, from the lowest: compound 3; then compound 1; then compounds 4 and 2 (each within the scatter of the next).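

The trifluoromethyl on the six-membered aromatic ring matters in this assay as much as the whole-group exchanges on the carbonyl: its loss gives a 65-fold higher number from compound 3 to compound 4 (1.82 log units; beyond the scatter) and places a single substituent among the large steps of the series. Without it, the 2-phenylethenyl group shows no difference from 1H-indol-2-yl, with a 1.4-fold lower number from compound 2 to compound 4 (0.13 log units; within the scatter) and thus within the scatter, and it falls well short of 1-benzofuran-2-yl, with a 22-fold higher number from compound 1 to compound 4 (1.35 log units; beyond the scatter) as the step. The lead of compound 3 over compound 1 therefore depends on this one substituent and not on the 2-phenylethenyl group alone, and no measurement at hand offers an explanation for the size of the step.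

Still open, from the compounds shown here alone, is whether the effect is particular to trifluoromethyl or would persist with a chlorine atom, a methoxy group or an amine on the same aromatic carbon. Also open, going by these compounds, is how a carboxylic acid at that carbon, or a longer chain between the carbonyl and the phenyl ring, would read in this assay.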